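Aryl variation at the shared core in melanoma cell growth inhibition

The source may report more compounds than this note shows. Statements on the series, on what has been measured and on what is new or still open speak of the compounds shown alone.

Compound 1 `c1ccc2c(-c3cn4ccnc4c(-c4ccc5ncn(C6CCCCC6)c5c4)n3)cccc2c1`: 4.06%
Compound 2 `Brc1ccc(-c2cn3ccnc3c(-c3ccc4ncn(C5CCCCC5)c4c3)n2)cc1`: 23.6%

Of the compounds shown here, two have been measured in a functional assay on SK-MEL-5 cells (Homo sapiens) for inhibition, read by sulforhodamine B assay, with a stated time of 48 h, tested at 10 uM; on this read-out higher numbers stand for more inhibition at the one concentration tested (going by the name of the read-out) and lower numbers for less inhibition. Compound 1 `c1ccc2c(-c3cn4ccnc4c(-c4ccc5ncn(C6CCCCC6)c5c4)n3)cccc2c1` gives 4.06%, and compound 2 `Brc1ccc(-c2cn3ccnc3c(-c3ccc4ncn(C5CCCCC5)c4c3)n2)cc1` gives 23.6%. Compound 2 stands highest of the two, and the step of a number 19.5 percentage points higher from compound 1 to compound 2 (beyond the scatter) lies beyond the scatter.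

Compound 3 `FC(F)(F)c1cccc(-c2cn3ccnc3c(-c3ccc4ncn(C5CCCCC5)c4c3)n2)c1` is not yet measured in this assay. Its difference from compound 2 is 3-(trifluoromethyl)phenyl in place of 4-bromophenyl on an aromatic carbon. For the measured compounds named here, no measured step involves this particular exchange; the only step recorded, a number 19.5 percentage points higher from compound 1 to compound 2 (beyond the scatter), concerns a different aryl group and so bears on compound 3 only loosely, showing that changes to this aryl group can move the read-out by a modest amount. With no closer guide, compound 3 is expected to land near compound 2, and the step of a number 5.6 percentage points lower from compound 2 to compound 3 (within the scatter) is estimated to fall within the scatter. For compound 3 the estimate in this assay is 18%, with a range from 3% to 38%.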

Compound 3, a percentage reported as inhibition, at one concentration (the size of the read-out at that concentration, not a potency): 4.32%
Compound 3: middle estimate off by 13.7 percentage points, on the high side; the measured number falls inside the stated range.
By their numbers in this assay, from the lowest: compounds 1 and 3 (each within the scatter of the next); then compound 2.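

The aryl position on the shared core proves more sensitive than a single exchange could show: in this assay, putting 3-(trifluoromethyl)phenyl in place of 4-bromophenyl gives a number 19.3 percentage points lower from compound 2 to compound 3 (beyond the scatter). Set against naphthalen-1-yl, the same 3-(trifluoromethyl)phenyl group gives a number 0.3 percentage points higher from compound 1 to compound 3 (within the scatter), so two quite different aryl groups read alike, and among these three compounds only the 4-bromophenyl group of compound 2 stands apart. Nothing available accounts for this difference.

The exchange from compound 2 to compound 3 alters both the substituent and its place on the phenyl ring, so the compounds shown leave open which of the two matters, a question that 3-bromophenyl and 4-(trifluoromethyl)phenyl would separate. From the compounds shown here alone, how an amine or a carboxylic acid on that phenyl ring would read also remains open.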